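The source may hold more compounds than are shown below. What is called first, only, known or untested is meant among the compounds shown, and "the series" means these compounds.

Compound 1 `COc1cc(-c2ccnc3cc(-c4ccc(C(C)(C)C)cc4)nn23)cc(OC)c1OC` is one of two members of this series with a number attached so far, and the other is compound 2 `Cc1ccc(-c2cc3nccc(-c4ccc(F)cc4)n3n2)cc1`, which carries a different pair of aryl groups on the shared core. In a functional assay on A549 cells (Homo sapiens) for inhibition, read by CCK-8 assay, with a stated time of 48 h (a higher number here means a weaker inhibitor, a lower number a stronger inhibitor), compound 1 gives only a limit, > 10000 nM, and no number. In the same assay compound 2 also returns a limit, > 10000 nM. Among the compounds with values here, both entries therefore sit at the limit of > 10000 nM in this assay, at which 2 of the 2 values shown sit, so compound 1 stands at the weak end of what this assay resolves, and no measured step exists within the set to gauge how a single change moves the read-out. Compound 3 `COc1cc(-c2ccnc3cc(-c4cn(C)c5ccccc45)nn23)cc(OC)c1OC` keeps everything else of compound 1 and differs by one exchange: 1-methyl-1H-indol-3-yl in place of 4-(tert-butyl)phenyl on an aromatic carbon. Within the data shown here, with no comparable step available, the expectation rests on the starting point alone. For compound 3 a step of a number no higher from compound 1 to compound 3 (the limit leaves the size open) is expected, that is, none beyond the scatter in either direction. Compound 3 is accordingly estimated at 10000 nM, with a range from 2000 nM to 50000 nM, and a limit rather than a number is the more likely outcome.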

Compound 3, half-maximal inhibitory concentration: 1340 nM
For compound 3 the middle estimate is 7.5-fold (0.87 log units) above the measured one; the whole stated range lies above it.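

In this assay, within the data shown here, on an aromatic carbon of the five-membered aromatic ring with 2 nitrogen, placing 1-methyl-1H-indol-3-yl in place of 4-(tert-butyl)phenyl gives an at least 7.4-fold lower number from compound 1 to compound 3 (0.87 log units; beyond the scatter), the first step that can be read, and it shows that the read-out responds to the group at this position even though the heavy-atom count stays the same and the entering group holds 1 hydrogen-bond acceptor against 0. From the compounds shown here alone, compound 1 gives > 10000 nM, which is a limit and not a number, so the true size of the step stays open at its upper end. Compound 3 is the only entry shown that resolves to a number: the limit of > 10000 nM in this assay, at which 2 of the 3 values shown sit.

Which feature of the entering group carries the step remains open, and a 1H-indol-3-yl with hydrogen rather than methyl on its nitrogen, or a phenyl bearing a carboxylic acid, at this carbon would begin to separate the possibilities. Also open, going by these compounds, is whether 1-methyl-1H-indol-3-yl gives a comparable step when the other aryl group on the shared core is changed.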